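Amide group change from compound 3 to compound 4

The source may report more compounds than this note shows. Statements on the series, on what has been measured and on what is new or still open speak of the compounds shown alone.

Measured in a functional assay on HeLa cells (Homo sapiens) for antiproliferative activity, read by sulforhodamine B assay, with a stated time of 48 h; a lower number here means a stronger inhibitor, a higher number a weaker inhibitor:
- compound 1 `COc1ccc(C[C@@H](O)/C=C/C=C/C(=O)N2CCCCC2)cc1OC`: 14100 nM
- compound 2 `COc1ccc(C[C@@H](O)/C=C/C=C/C(=O)N2CCN(C)CC2)cc1OC`: 16500 nM
- compound 3 `COc1ccc(C[C@@H](O)/C=C/C=C/C(=O)N2CCCC2)cc1OC`: 14100 nM

Compound 3, at 14100 nM, is level with compound 1 at the digits given, and compound 2 lies within the scatter of both. The next compound to be read is compound 4 `COc1ccc(C[C@@H](O)/C=C/C=C/C(=O)NCc2ccccc2)cc1OC`, with benzylamino in place of pyrrolidin-1-yl on a carbonyl carbon.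

For the measured compounds named here, three measured steps bear on this change, all at the same carbonyl carbon: no change at the digits printed from compound 1 to compound 3 (within the scatter), a 1.2-fold higher number from compound 1 to compound 2 (0.07 log units; within the scatter) and a 1.2-fold lower number from compound 2 to compound 3 (0.07 log units; within the scatter). All three are within the scatter, so swapping these groups has so far left this assay flat. That evidence is limited, however. Compounds 1, 2 and 3 all carry a non-aromatic ring at this carbon, and none has the six-membered aromatic ring of carbon only or the hydrogen-bond donor that benzylamino brings. The flat steps therefore support a central expectation of no real shift, but they justify a wide range in either direction.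

The expected step is a 1.1-fold lower number from compound 3 to compound 4 (0.04 log units; within the scatter), which means no change beyond the scatter is expected. For compound 4 the estimated value is 13000 nM, with an expected range of 4500 nM to 35000 nM.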

Compound 4, half-maximal inhibitory concentration: 12900 nM
The estimate for compound 4 lay 1.0-fold (0.00 log units) above the measured number; low and high end bracket the measured number.
By their numbers in this assay, from the lowest: compounds 4, 1, 3 and 2 (each within the scatter of the next).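

In this assay the steps to the benzylamino amide read a 1.1-fold lower number from compound 3 to compound 4 (0.04 log units; within the scatter) and a 1.1-fold lower number from compound 1 to compound 4 (0.04 log units; within the scatter) and a 1.3-fold lower number from compound 2 to compound 4 (0.11 log units; within the scatter) and all stay within the scatter. The flat picture at this carbonyl carbon therefore no longer rests on non-aromatic rings alone: it now also holds for a group with a six-membered aromatic ring of carbon only and 1 hydrogen-bond donor, so neither feature separates compound 4 from compounds 1, 2 and 3 in this read-out. Nothing among the data shown accounts for why these four amides read alike.

As far as these compounds go, every group seen at this carbon so far carries no net charge, so it remains open whether an amide bearing a carboxylic acid or a free primary amine, or one with a longer chain between the amide nitrogen and the phenyl ring, would move the number beyond the scatter. All four compounds also share the same core, which leaves open whether replacing the hydroxyl group or the two methoxy groups would matter more than any change at the amide.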